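Replacing 3,4-dichlorophenyl with 2,3,4-trifluorophenyl in the series

The compounds below may be only part of what the source reports. "The series", "measured", "known", "first", "only" and "open" are said of these compounds alone.

In a functional assay on MCF cells (Homo sapiens) for antiproliferative activity, with a stated time of 72 h (a lower number here means a stronger inhibitor, a higher number a weaker inhibitor), compound 1 `COc1cccc(CNc2ncnc3c2ncn3[C@@H]2O[C@H](CO)[C@@H](O)[C@H]2O)c1` gives > 166000 nM as a limit of the assay and not a number. Compound 2 `OC[C@H]1O[C@@H](n2cnc3c(NCc4ccc(Cl)cc4Cl)ncnc32)[C@H](O)[C@@H]1O` gives 127000 nM in the same read-out and compound 3 `OC[C@H]1O[C@@H](n2cnc3c(NCc4ccc(Cl)c(Cl)c4)ncnc32)[C@H](O)[C@@H]1O` gives 88800 nM on the same scale. Going by the values given here, compound 3 therefore stands level with compound 2, with a 1.4-fold lower number from compound 2 to compound 3 (0.16 log units; within the scatter) as the only step between two true numbers. The steps from compound 1 are an at least 1.3-fold lower number from compound 1 to compound 2 (0.11 log units; that floor lies within the scatter) and an at least 1.8-fold lower number from compound 1 to compound 3 (0.27 log units; that floor lies within the scatter) and both start from the limit of > 166000 nM in this assay, at which 1 of the 3 values shown sits, as their reference.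

Compound 4 `OC[C@H]1O[C@@H](n2cnc3c(NCc4ccc(F)c(F)c4F)ncnc32)[C@H](O)[C@@H]1O` carries 2,3,4-trifluorophenyl in place of 3,4-dichlorophenyl on a saturated chain carbon bound to a nitrogen on an aromatic ring, with 2,3,4-trifluorophenyl in place of 3,4-dichlorophenyl on a saturated chain carbon bound to a nitrogen on an aromatic ring as the count. Among the compounds with values here, no fluorinated compound has been measured. The closest guide is compound 3 with a 1.4-fold lower number from compound 2 to compound 3 (0.16 log units; within the scatter) as its step, so no shift beyond the scatter is expected in this assay here. The expected change is a 1.2-fold higher number from compound 3 to compound 4 (0.09 log units; within the scatter) on this estimate. Compound 4 is expected at 110000 nM with an estimated range of 45000 nM to 170000 nM in this read-out.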

Compound 4, half-maximal inhibitory concentration: > 166000 nM
Compound 4 was reported as a limit; the forecaster's own chance of this, stated with the estimate: 35%; middle value at least 1.5-fold (0.17 log units) from the limit.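

Compound 4 gives > 166000 nM in this assay, a limit of the assay and not a number. Against it, an at least 1.8-fold higher number from compound 3 to compound 4 (0.27 log units; that floor lies within the scatter) and an at least 1.3-fold higher number from compound 2 to compound 4 (0.11 log units; that floor lies within the scatter) are floors only, so 2,3,4-trifluorophenyl in place of either dichlorophenyl group is not shown to shift the read-out beyond the scatter, and the step between compound 1 and compound 4 cannot be read. On the saturated chain carbon bound to a nitrogen on an aromatic ring, only the two dichlorophenyl compounds, compound 2 and compound 3, now give true numbers, while compound 1 and compound 4 sit together: the limit of > 166000 nM in this assay, at which 2 of the 4 values shown sit.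

From the compounds shown here alone, how far compound 1 and compound 4 lie past that limit stays unknown. Also open, going by these compounds, is whether a trifluoromethyl group or an amine on the phenyl ring, or a longer chain in place of the saturated chain carbon, would give a true number in this assay.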